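A few compounds are considered here, and "the series" means these few. Any claim that something is new, unique, unknown or untested is made for them only; others in the source may bear on it.

Measured so far in a functional assay on MV4-11 cells (Homo sapiens) for inhibition, with a stated time of 120 h, tested at 10 uM; a higher number here means more inhibition at the concentration tested (going by the name of the read-out), a lower number less inhibition:
compound 1 `Cc1n[nH]c2ccc(-c3nc4cnc(N5CCC(C)CC5)cn4c3Nc3ccc(Cl)cc3)cc12` gives 28%
compound 2 `Cc1ccc(C)c(Nc2c(-c3ccc4[nH]nc(C)c4c3)nc3cnc(N4CCN(C)CC4)cn23)c1` gives 0%

Compound 2 stands lowest of the two numbers; compound 1 sits higher by a gap beyond the scatter, the two differing in more than one place, so only the two values themselves are known.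

Compound 3 `Cc1n[nH]c2ccc(-c3nc4cnc(N5CCN(C)CC5)cn4c3Nc3cc(Cl)ccc3Cl)cc12` is not yet measured. The change from compound 2: 2,5-dichlorophenyl in place of 2,5-dimethylphenyl on a nitrogen on an aromatic ring. Within the data shown here, no single-point step between measured compounds is known, so the expected step in this assay, a number 10 percentage points higher from compound 2 to compound 3 (within the scatter), is small and upward, not clearly beyond the scatter. Compound 3 is estimated at 10%, within 0% to 30%.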

Compound 3, a percentage reported as inhibition, at one concentration (the size of the read-out at that concentration, not a potency): 23.8%
Beside the measured number, compound 3's estimate is 13.8 percentage points below it; the measured number falls inside the stated range.
By their numbers in this assay, from the lowest: compound 2; then compounds 3 and 1 (each within the scatter of the next).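

In this assay, among these compounds, the change from 2,5-dimethylphenyl to 2,5-dichlorophenyl on the nitrogen gives the first single-point step, a number 23.8 percentage points higher from compound 2 to compound 3 (beyond the scatter) with the rest of the structure unchanged. This position therefore registers a swap of two methyl groups for two chlorine atoms, although the heavy-atom count and the donor and acceptor counts stay the same. No evidence is available to explain the step.

From the compounds shown here alone, whether one chlorine alone would carry this step remains open, as does how 2,5-difluorophenyl or 2,5-dimethoxyphenyl would read at this position.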